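The source may hold more compounds than are shown below. What is called first, only, known or untested is meant among the compounds shown, and "the series" means these compounds.

Measured compounds in an ADME assay on MDCK cells (Canis lupus familiaris) for permeability, read by LC-MS, with a stated time of 90 min, tested at 2 uM; a higher number here means that the compound crosses the layer faster, a lower number that the compound crosses the layer more slowly:
Compound 1 `Cc1cc(C)c(CN2CCc3c(Cl)cc(-c4c(C)noc4C)c(Cl)c3C2=O)c(=O)[nH]1` gives 15.7 10^-6 cm/s.
Compound 2 `COc1cc(C)[nH]c(=O)c1CN1CCc2c(Cl)cc([C@H](O)C3COC3)c(Cl)c2C1=O` gives 0.7 10^-6 cm/s.
Compound 3 `COc1cc(C)[nH]c(=O)c1CN1CCc2c(Cl)cc(C(OC)C3(C)COC3)c(Cl)c2C1=O` gives 5.7 10^-6 cm/s; 4.8 10^-6 cm/s (2 entries); the agreement of its repeat entries is shown by the several entries of compound 3 in this assay, 5.7 10^-6 cm/s; 4.8 10^-6 cm/s (2 entries).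

Compound 2 stands lowest of the two single numbers in this assay. Its nearest neighbour is compound 1, whose apparent permeability is far higher, a gap that lies beyond the scatter of the assay; compound 3 contributes a further entry without a single number. The unmeasured compound 4 `COc1cc(C)[nH]c(=O)c1CN1CCc2c(Cl)cc(-c3c(C)noc3C)c(Cl)c2C1=O` differs from compound 2 in one place: a group of 7 heavy atoms (5 carbon, 1 nitrogen, 1 oxygen; one five-membered aromatic ring with 2 hetero atoms) in place of a group of 6 heavy atoms (4 carbon, 2 oxygen; one four-membered non-aromatic ring with 1 hetero atom), on an aromatic carbon. Among the measured compounds shown here, no step between two measured compounds is available that isolates this change, so the size of the step is taken from the standing of the compounds themselves. Compound 1 carries the same 3,5-dimethyl-1,2-oxazol-4-yl group on the shared core and gives 15.7 10^-6 cm/s, while compound 2 with its four-membered ring and hydrogen-bond donor gives 0.7 10^-6 cm/s. A clear rise is therefore expected, the estimated step being a 14-fold higher number from compound 2 to compound 4 (1.15 log units; beyond the scatter). For compound 4 the expected apparent permeability in this assay is 10 10^-6 cm/s, within a range from 4 10^-6 cm/s to 22 10^-6 cm/s.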

Compound 4, apparent permeability: 11 10^-6 cm/s
Estimate against measurement, compound 4: 1.1-fold (0.04 log units) below, within the range that was stated.
By their numbers in this assay, from the lowest: compound 2; then compounds 4 and 1 (each within the scatter of the next).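

On the aromatic carbon ortho to a chloro group, 3,5-dimethyl-1,2-oxazol-4-yl in place of the group with the four-membered ring gives a 16-fold higher number from compound 2 to compound 4 (1.20 log units; beyond the scatter) in this assay, so the large gap now has a step in one place, with the methoxy group present on both sides. Methoxy in place of methyl on an aromatic carbon, with 3,5-dimethyl-1,2-oxazol-4-yl held fixed, gives a 1.4-fold lower number from compound 1 to compound 4 (0.15 log units; within the scatter), so this second change does not separate the two compounds. The large step also stands far apart from the agreement between repeats: the several entries of compound 3 in this assay, 5.7 10^-6 cm/s; 4.8 10^-6 cm/s (2 entries).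

From the compounds shown here alone, the hydrogen-bond donor, the four-membered ring and the stereocentre all leave together, so their separate shares in the step remain open. Going by these compounds, how a phenyl ring or an amine on this carbon would stand in this assay also remains open.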